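The compounds below may be only part of what the source reports. "The series", "measured", "known", "first", "only" and "open" are said of these compounds alone.

Compound 2 `Cc1ccc(S(=O)(=O)N(Cc2cn(Cc3ccccc3)nn2)Cc2c(-c3ccccc3)c3ccccc3n2S(=O)(=O)c2ccc(C)cc2)cc1` sits at the upper end of the two numbers measured in a functional assay on 3T3-L1 cells (Mus musculus) for inhibition, with a stated time of 20 min, tested at 20 uM (on this read-out lower numbers stand for less inhibition and higher numbers for more inhibition at the one concentration tested (going by the name of the read-out)), where compound 2 gives 0.03%. Its nearest neighbour, compound 1 `COc1cc(Cn2cc(CN(Cc3c(-c4ccccc4)c4ccccc4n3S(=O)(=O)c3ccc(C)cc3)S(=O)(=O)c3ccc(C)cc3)nn2)cc(OC)c1OC`, gives -10.9% in this assay, and the step of a number 10.9 percentage points higher from compound 1 to compound 2 (beyond the scatter) lies beyond the scatter, though both numbers sit close to no inhibition. Compound 3 `Cc1ccc(S(=O)(=O)N(Cc2cn(Cc3ccccc3)nn2)Cc2c(C)c3ccccc3n2S(=O)(=O)c2ccc(C)cc2)cc1` differs from compound 2 in one place: methyl in place of phenyl on an aromatic carbon. Among the compounds with values here, the change sits on an aromatic carbon of a five-membered aromatic ring with one nitrogen, two ring bonds from the ring nitrogen, a site untouched by the single measured step, which altered only the group on the saturated chain carbon bound to an aromatic nitrogen. Within the data shown here, no measured step therefore speaks to this change, and with both known numbers near zero, compound 3 is expected to stay within the scatter, the step of a number 0 percentage points lower from compound 2 to compound 3 (within the scatter) being essentially none. In this assay compound 3 is estimated at 0%, between -15% and 15%.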

Compound 3, a percentage reported as inhibition, at one concentration (the size of the read-out at that concentration, not a potency): -5.9%
Compound 3: the middle estimate sits 5.9 percentage points above what was measured; the measured number falls inside the stated range.
By their numbers in this assay, from the lowest: compounds 1, 3 and 2 (each within the scatter of the next, the first and the last beyond it).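

In this assay, within the data shown here, the first change at this aromatic carbon of the five-membered ring gives a number 5.9 percentage points lower from compound 2 to compound 3 (within the scatter) and so stays within the scatter, even though a phenyl of six heavy atoms gives way to a methyl of one. At this one concentration, then, neither group at this position gives a number that stands clear of the other, and the shortened substituent brings no inhibition into view. Nothing on hand offers an explanation for this result.

On these data alone, whether an amine, a carboxylic acid or a longer chain at this aromatic carbon would move the number beyond the scatter remains open. Also open, as far as these compounds go, is whether methyl in place of phenyl would read the same with a 3,4,5-trimethoxyphenyl group on the saturated chain carbon bound to the aromatic nitrogen.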